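The source may hold more compounds than are shown below. What is called first, only, known or untested is meant among the compounds shown, and "the series" means these compounds.

Measured so far:
Compound 1 `O=S(=O)(Nc1ccc2oc(-c3ccccc3)nc2c1)c1cccc(Cl)c1`. In an assay on cells for inhibition of HSP60/HSP10 (Homo sapiens), with a stated time of 60 min (a lower number here means a stronger inhibitor, a higher number a weaker inhibitor), compound 1 gives > 100000 nM, which is a limit of the assay rather than a number.
Compound 2 `O=S(=O)(Nc1ccc2oc(-c3ccccc3)nc2c1)c1cccc(O)c1`. In this assay compound 2 gives 76000 nM.

Within the data shown here, compound 2 therefore stands as the only compound with an actual number in this assay; the other entry is a limit. Among the measured compounds shown here, the one measured step between them, an at least 1.3-fold lower number from compound 1 to compound 2 (0.11 log units; that floor lies within the scatter), is known only as a floor, because it starts from the limit of > 100000 nM in this assay, at which 1 of the 2 values shown sits, and so cannot be pinned to a size.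

Compound 3 `COc1ccc(S(=O)(=O)Nc2ccc3oc(-c4ccccc4)nc3c2)cc1` differs from compound 2 by 4-methoxyphenyl in place of 3-hydroxyphenyl on a sulfonyl sulfur. For the measured compounds named here, no measured step touches this kind of change: the only step on record swaps a hydroxy for a chloro at the same place, and even that step is a floor rather than a size. There is thus nothing to point to a shift beyond the scatter in either direction, and a number close to that of compound 2 seems the most reasonable expectation.

Compound 3 is estimated at 80000 nM, with a range from 25000 nM to 250000 nM, and it may well be reported only as a limit.

The expected step is a 1.1-fold higher number from compound 2 to compound 3 (0.02 log units; within the scatter).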

Compound 3, half-maximal inhibitory concentration: > 100000 nM
Compound 3 was reported as a limit (the forecaster's own chance of this, stated with the estimate: 40%); middle value at least 1.2-fold (0.09 log units) from the limit.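

Going from the 3-hydroxyphenyl to the 4-methoxyphenyl on the sulfonyl sulfur removes the only hydrogen-bond donor of that group, 1 against 0, and the result is an at least 1.3-fold higher number from compound 2 to compound 3 (0.11 log units; that floor lies within the scatter). Among these three compounds, compound 2 is now the only one with an actual number in this assay, since compound 1 with its 3-chlorophenyl and compound 3 with its 4-methoxyphenyl both end at a limit of the assay rather than a number. The step from compound 2 to compound 3 therefore has no known size, and the step between compound 1 and compound 3 cannot be read at all, because both compounds sit at the same limit: the limit of > 100000 nM in this assay, at which 2 of the 3 values shown sit.

The compounds shown leave open whether it is the hydroxy itself or the place it occupies on the ring that sets compound 2 apart, as compound 3 alters both the group and its place on the ring in a single step. They also leave open what an amine or a carboxylic acid on this ring would do to the number, and whether any group on the sulfonyl sulfur can bring it much lower than that of compound 2.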